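From Ethynyl to Vinyl: Expecting Another Limit

The source may hold more compounds than are shown below. What is called first, only, known or untested is meant among the compounds shown, and "the series" means these compounds.

Measured so far in a functional assay on HCT-116 cells (Homo sapiens) for cytotoxicity, with a stated time of 3 days; a lower number here means a stronger inhibitor, a higher number a weaker inhibitor:
compound 1 `Ic1nc2ccccc2o1` — > 40000 nM, a limit of the assay
compound 2 `C#Cc1csc(Br)n1` — > 40000 nM, a limit of the assay

Compound 1 gave no number in this assay, only a limit. Compound 2 likewise gave only a limit, > 40000 nM. Compound 2 thus stands at the limit of > 40000 nM in this assay, at which 2 of the 2 values shown sit. For the measured compounds named here, no two measured compounds differ in a single place, so no step between measured compounds can be sized here.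

Compound 3 `C=Cc1csc(Br)n1` is not yet measured. It differs from compound 2 by vinyl in place of ethynyl on an aromatic carbon. Going by the values given here, nothing among the measured compounds shows what this change does in this assay. Since compound 2 reached only the limit, > 40000 nM, the step that the limit leaves unreadable from compound 2 to compound 3 is expected to be none beyond the scatter. Compound 3 is therefore estimated at 50000 nM, within 15000 nM to 200000 nM, and is most likely to be reported again only as a limit.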

Compound 3, half-maximal inhibitory concentration: > 40000 nM
Compound 3 gave a limit, no number; the forecaster's own chance of this, stated with the estimate: 80%; the middle value does not contradict the limit.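

Compound 3 gave only a limit, > 40000 nM. Compound 2 also gave only a limit, > 40000 nM, so the change from ethynyl to vinyl yields no readable step. The compounds shown leave open which structure, if any, would give an actual number, as all stand together: the limit of > 40000 nM in this assay, at which 3 of the 3 values shown sit.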